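The source may hold more compounds than are shown below. What is called first, only, known or untested is meant among the compounds shown, and "the series" means these compounds.

Measured compounds:
Compound 1 `O=C(O)CCCSCCN1C(=O)OC[C@@H]1/C=C/[C@@H](O)Cc1cccc(C(F)(F)F)c1`, in an in vivo ADME assay on the whole organism for pharmacokinetics, with Rattus norvegicus as the target (a higher number here means that more of the compound sits outside the plasma, a lower number that more of the compound stays in the plasma), compound 1 gives 0.631 L/kg.
Compound 2 `CCCc1cccc(C[C@H](O)/C=C/[C@H]2CSC(=O)N2CCSCCCC(=O)O)c1`, in this assay compound 2 gives 1.28 L/kg.

Compound 2 holds the higher of the two numbers, with compound 1 lower by a gap beyond the usual scatter. The next compound, compound 3 `O=C(O)CCCSCCN1C(=O)SC[C@@H]1/C=C/[C@@H](O)Cc1cccc(C(F)(F)F)c1`, keeps the core of compound 2 and carries trifluoromethyl in place of propyl on an aromatic carbon. For the measured compounds named here, no measured pair shows this change on its own. Compound 3 is expected to sit below compound 2, as a step of modest size a 1.4-fold lower number from compound 2 to compound 3 (0.15 log units; within the scatter), possibly within the scatter. The estimate for compound 3 in this assay is 0.9 L/kg, between 0.5 L/kg and 1.6 L/kg.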

Compound 3, volume of distribution at steady state: 0.512 L/kg
The estimate for compound 3 lay 1.8-fold (0.24 log units) above the measured number; the measured number falls inside the stated range.
By their numbers in this assay, from the lowest: compounds 3 and 1 (each within the scatter of the next); then compound 2.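

In this assay, for the compounds shown here, trifluoromethyl in place of propyl on an aromatic carbon gives a 2.5-fold lower number from compound 2 to compound 3 (0.40 log units; beyond the scatter), the first reading of this change on its own, and it shows that this position alone can move the number beyond the scatter. Compound 3 and compound 1 stand within the scatter of each other, so both trifluoromethyl compounds lie in one band, under compound 2. Nothing measured here bears on why the number moves.

Whether the step carries over to the core of compound 1 remains open, as that core has no propyl partner among the compounds shown. Also open, going by these compounds, is how an ethyl, a methoxy or a longer chain at this position would read.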